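A few compounds are considered here, and "the series" means these few. Any claim that something is new, unique, unknown or untested is made for them only; others in the source may bear on it.

Compound 3 `CCN(C/C=C/C#CC(C)(C)C)Cc1cccc(OC[Si](C)(C)c2cccc(C)c2)c1` stands at the top of the numbers gathered so far in a functional assay on liver (Sus scrofa) for inhibition of squalene monooxygenase (Homo sapiens), using microsomes (a higher number here means a weaker inhibitor, a lower number a stronger inhibitor), where compound 3 gives 3000 nM. Compound 2 `CCN(C/C=C/C#CC(C)(C)C)Cc1cccc(OC[Si](C)(C)c2ccc(Cl)cc2)c1` gives 400 nM in this assay, and compound 1 `CCN(CC#CC#CC(C)(C)OC)Cc1cccc(OC[Si](C)(C)c2ccccc2C)c1`, which differs from the others in several places at once, gives 70 nM. Among the compounds with values here, the one single-point comparison recorded is a 7.5-fold higher number from compound 2 to compound 3 (0.88 log units; beyond the scatter), an exchange of the group on the silicon.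

Compound 4 `CCN(C/C=C/C#CC(C)(C)C)Cc1cccc(OC[Si](C)(C)c2ccc(C=O)cc2)c1` is not yet measured. It differs from compound 3 in one place: 4-formylphenyl in place of 3-methylphenyl on a silicon. The step from compound 2 to compound 3 bears on this change, since it too swapped the aryl group on the silicon, and it was modest in size, a 7.5-fold higher number from compound 2 to compound 3 (0.88 log units; beyond the scatter). Compound 1 offers no single-point comparison. Because compound 2 gives 400 nM with a different aryl group on the silicon, a move away from 3-methylphenyl is expected to lower the number again, though with some uncertainty. Compound 4 is therefore expected to give about 700 nM in this assay, within a range from 200 nM to 2500 nM. This estimate corresponds to a step of a 4.3-fold lower number from compound 3 to compound 4 (0.63 log units; beyond the scatter), which is expected to reach beyond the scatter.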

Compound 4, half-maximal inhibitory concentration: 100 nM
Estimate against measurement, compound 4: 7.0-fold (0.85 log units) above; the whole stated range lies above it.
By their numbers in this assay, from the lowest: compounds 1 and 4 (each within the scatter of the next); then compound 2; then compound 3.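

In this assay, the exchange of 3-methylphenyl for 4-formylphenyl on the silicon gives a 30-fold lower number from compound 3 to compound 4 (1.48 log units; beyond the scatter) and so shows that this place can move the number much further than the modest earlier step suggested. Within the data shown here, the comparison with compound 2 adds that the choice of group on the aromatic ring still matters when only that group changes: formyl in place of chloro gives a 4.0-fold lower number from compound 2 to compound 4 (0.60 log units; beyond the scatter) and is beyond the scatter, so 4-chlorophenyl does not mark the low end of what this place allows. The entering group also brings a carbonyl and one hydrogen-bond acceptor that the leaving group lacks, but nothing at hand tells why the number falls with this change.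

Going by these compounds, it remains open whether a nitrile, an acetyl group or a hydroxymethyl group in place of the formyl would hold the number as low as in compound 4. Also open, on these data alone, are whether 3-formylphenyl would behave like 4-formylphenyl on the silicon, and whether the formyl group would have a similar effect with the different chain of compound 1.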